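Swapping the aryl group beside the carbonyl in a sulfonyl chalcone

A few compounds are considered here, and "the series" means these few. Any claim that something is new, unique, unknown or untested is made for them only; others in the source may bear on it.

Compound 1 `O=C(/C(=C\c1ccc(Br)c(O)c1)S(=O)(=O)c1ccc(Br)cc1)c1ccc(Br)cc1` and compound 2 `Cc1ccc(C(=O)/C(=C\c2ccc(N(C)C)cc2)S(=O)(=O)c2ccc(Cl)cc2)cc1` share a core with two halogenated aryl groups. In a functional assay on DU-145 cells (Homo sapiens) for inhibition, read by trypan blue exclusion, with a stated time of 96 h (on this read-out higher numbers stand for weaker inhibition of growth and lower numbers for stronger inhibition of growth), compound 1 gives 50000 nM, and in this assay compound 2 gives 50000 nM; compound 1 is therefore level with compound 2, within the scatter. Compound 3 `COc1cccc(OC)c1/C=C(\C(=O)c1ccc(Br)cc1)S(=O)(=O)c1ccc(Br)cc1` carries a single change from compound 1: 2,6-dimethoxyphenyl in place of 4-bromo-3-hydroxyphenyl on a double-bonded chain carbon bound to a double-bonded chain carbon. With both measured compounds equally weak, a step of a 1.4-fold lower number from compound 1 to compound 3 (0.15 log units; within the scatter) is expected, that is none beyond the scatter. Compound 3 is estimated at 35000 nM, in a range from 8000 nM to 50000 nM.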

Compound 3, concentration for 50% growth inhibition: 10000 nM
Compound 3: the middle estimate sits 3.5-fold (0.54 log units) above what was measured; measured number inside the range.
By their numbers in this assay, from the lowest: compound 3; then compounds 1 and 2 (each within the scatter of the next).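

The aryl group on a double-bonded chain carbon bound to a double-bonded chain carbon matters in this assay: 2,6-dimethoxyphenyl in place of 4-bromo-3-hydroxyphenyl gives a 5.0-fold lower number from compound 1 to compound 3 (0.70 log units; beyond the scatter), a modest gain in growth inhibition. The earlier pair, level with each other, could not show this. Nothing available explains why this change strengthens inhibition.

Among these compounds, the single swap changes the oxygen groups and removes the bromine together, so their separate contributions remain open. From the compounds shown here alone, how a carboxylic acid or a morpholine ring would fare at this position also remains open.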